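Chloro to methyl on the aryl ring: compound 4

This account rests on a few compounds, and the source may have more. Where it says the series, first, only, none or still open, it means among the compounds named here.

Measured compounds in a functional assay on the whole organism with Mus musculus as the target, in the maximal electroshock model; a higher number here means that more compound is needed for the effect, a lower number that less compound is needed:
- compound 1 `Cc1ccc(-c2ccc(N3CCC(O)CC3)nn2)c(Cl)c1` gives 21 mg/kg
- compound 2 `OC1CCN(c2ccc(-c3cc(Cl)ccc3Cl)nn2)CC1` gives 30 mg/kg
- compound 3 `OC1CCN(c2ccc(-c3cccc(Cl)c3)nn2)CC1` gives 45 mg/kg

Compound 3 stands at the highest number of the three. Within the data shown here, compound 2 sits nearest to it, and the only single-place step among the measured compounds, a 1.5-fold higher number from compound 2 to compound 3 (0.18 log units; within the scatter), is within the scatter, so these two cannot be told apart. Compound 1 is the furthest from compound 3 and carries the lower number, but it differs from compound 3 in more than one place, so no single step can be read from that pair.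

Compound 4 `Cc1cccc(-c2ccc(N3CCC(O)CC3)nn2)c1` is unmeasured. It arises from compound 3 by methyl in place of chloro on an aromatic carbon.

Among the measured compounds shown here, no measured step bears on this change directly: the one step on hand, from compound 2 to compound 3, swaps chloro for hydrogen and stays within the scatter. Compound 1, which carries a methyl, gives a lower number than compound 3 but cannot be isolated as a single change. On this basis the step of a 1.1-fold lower number from compound 3 to compound 4 (0.05 log units; within the scatter) is expected to stay within the scatter, with no direction called.

Compound 4 is therefore estimated at 40 mg/kg in this assay, with a range from 20 mg/kg to 80 mg/kg.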

Compound 4, dose for half-maximal effect: 36 mg/kg
For compound 4 the middle estimate is 1.1-fold (0.05 log units) above the measured one, within the range that was stated.
By their numbers in this assay, from the lowest: compounds 1, 2, 4 and 3 (each within the scatter of the next, the first and the last beyond it).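

In this assay, methyl in place of chloro on an aromatic carbon, meta to a large group, gives a 1.3-fold lower number from compound 3 to compound 4 (0.10 log units; within the scatter), so the two groups cannot be told apart at this place. This is the first single-place change shown for the chloro that compound 3 retains, as the earlier step, a 1.5-fold higher number from compound 2 to compound 3 (0.18 log units; within the scatter), concerned the loss of a different chloro and offered no comparison between a chloro and a methyl. Nothing measured here bears on why the two groups give values that cannot be separated.

Still open is whether this place tolerates change more broadly: the compounds shown do not reveal whether hydrogen, methoxy, trifluoromethyl, an amine or a carboxylic acid there would move the number in this assay beyond the scatter. The pairs of compound 1 with compound 3 and with compound 4 differ in more than one place and cannot be read as steps, so the contribution of each substituent in compound 1 also remains unresolved.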